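Benzyl ether variations on the shared core: notes toward compound 4

This account rests on a few compounds, and the source may have more. Where it says the series, first, only, none or still open, it means among the compounds named here.

Measured so far in an ADME assay on Huh-5-2 cells (Homo sapiens) for cytotoxicity, read by WST assay, with a stated time of 3 days; on this read-out lower numbers stand for higher toxicity in this test and higher numbers for lower toxicity in this test:
- compound 1 `O=c1c(OCc2ccccc2[N+](=O)[O-])c(-c2ccccc2)oc2cc(O)cc(O)c12` gives 51000 nM
- compound 2 `COc1ccccc1COc1c(-c2ccccc2)oc2cc(O)cc(O)c2c1=O` gives 53000 nM
- compound 3 `COc1cccc(COc2c(-c3ccccc3)oc3cc(O)cc(O)c3c2=O)c1` gives 28000 nM

Compound 3 holds the lowest of the three numbers, yet its gaps to compound 1 and compound 2 both stay within the scatter, so no order among the three can be claimed.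

The next compound, compound 4 `O=c1c(OCc2ccc(Br)cc2)c(-c2ccccc2)oc2cc(O)cc(O)c12`, differs from compound 3 in one place: 4-bromophenyl in place of 3-methoxyphenyl on a saturated chain carbon bound to an oxygen on an aromatic ring.

Two measured steps change the same aryl group on the same benzyl position. From compound 1 to compound 3 the result was a 1.8-fold lower number from compound 1 to compound 3 (0.26 log units; within the scatter), and from compound 2 to compound 3 it was a 1.9-fold lower number from compound 2 to compound 3 (0.28 log units; within the scatter). Neither swap of the aryl substituent moved this assay beyond its scatter, and the swap of nitro for methoxy, a 1.0-fold higher number from compound 1 to compound 2 (0.02 log units; within the scatter), did not either. For compound 4 the expectation is therefore no step beyond the scatter, expressed as a 1.4-fold higher number from compound 3 to compound 4 (0.13 log units; within the scatter).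

Compound 4 is estimated at 38000 nM, with an expected range from 15000 nM to 90000 nM.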

Compound 4, half-maximal cytotoxic concentration: 2000 nM
The estimate for compound 4 lay 19-fold (1.28 log units) above the measured number, outside the stated range (below it).
By their numbers in this assay, from the lowest: compound 4; then compounds 3, 1 and 2 (each within the scatter of the next).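

In this assay the aryl group on a saturated chain carbon bound to an oxygen on an aromatic ring can move the read-out well beyond the scatter: 4-bromophenyl in place of 3-methoxyphenyl gives a 14-fold lower number from compound 3 to compound 4 (1.15 log units; beyond the scatter). The same holds for 4-bromophenyl in place of 2-methoxyphenyl, with a 27-fold lower number from compound 2 to compound 4 (1.42 log units; beyond the scatter), and in place of 2-nitrophenyl, with a 26-fold lower number from compound 1 to compound 4 (1.41 log units; beyond the scatter). This position, which showed no step beyond the scatter among the methoxy and nitro compounds, is therefore not indifferent to the aryl group, and compound 4 stands apart as the most toxic of the four in this test.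

No evidence at hand gives a reason for this drop. Open is whether the step follows bromine or the 4-substituted pattern, since the compounds shown include no 3-bromophenyl or 4-methoxyphenyl, and none with chlorine, an amine or a carboxylic acid on that ring.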